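A few compounds are considered here, and "the series" means these few. Any claim that something is new, unique, unknown or untested is made for them only; others in the source may bear on it.

Working notes on the series.

Within the data shown here, the one number in hand comes from compound 1 `Nc1nccc(-c2ccc3nc(C4COc5ccc(F)cc5C4)oc3c2)n1`, which in an assay on cells for inhibition of Rho-associated protein kinase 2 (Homo sapiens) (on this read-out lower numbers stand for stronger inhibition and higher numbers for weaker inhibition), gives 28 nM. Compound 2 `COC(=O)c1ccc2c(c1)CC(c1nc3ccc(-c4ccnc(N)n4)cc3o1)CO2` carries a methyl ester on its core and in this assay stands at "not determined" (no result reported). Compound 3 `Cc1[nH]ncc1-c1ccc2nc(C3COc4ccccc4C3)[nH]c2c1` is in the same position: in this assay it is recorded as "not determined" (no result reported), so no single number exists for it, and compound 2 is the one further entry without a number. Compound 3 therefore cannot be placed against compound 1 on this assay, and nothing can be said about where it stands beyond the absence of a result.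

Compound 4 `c1ccc2c(c1)CC(c1nc3ccc(-c4ccncc4)cc3[nH]1)CO2` is the next compound to be measured. It differs from compound 3 in one place: pyridin-4-yl in place of 5-methyl-1H-pyrazol-4-yl on an aromatic carbon. Among the measured compounds shown here, as no step between measured compounds exists anywhere in the set, the size and direction of this change in this assay are unanchored; the only reference is that compound 1, with a different group at the same kind of position on its core, gives 28 nM. The step from compound 3 is expected to be of unknown size, and the expectation for compound 4 rests on compound 1 alone. For compound 4 in this assay a value of about 120 nM is estimated, within a range from 20 nM to 700 nM.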

Compound 4, half-maximal inhibitory concentration: < 6 nM
Compound 4 ended at the assay's limit; the forecaster's own chance of this, stated with the estimate: 10%; middle value at least 20-fold (1.30 log units) from the limit.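

In this assay compound 4 gives < 6 nM, which is a limit of the assay and not a number. Among these compounds, compound 3 has no single number there, so no step between compound 3 and compound 4 can be read. The compounds shown leave open how pyridin-4-yl and 5-methyl-1H-pyrazol-4-yl compare on this read-out.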